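Adding 3-methoxyphenyl to the triazole aryl on two cores

The source may report more compounds than this note shows. Statements on the series, on what has been measured and on what is new or still open speak of the compounds shown alone.

Compound 1 `COc1ccc(-c2cn(-c3cc4ccc(O)c(C)c4oc3=O)nn2)cc1` and compound 3 `COc1cccc(-c2cc(-c3cn(-c4cc5ccc(O)c(C)c5oc4=O)nn3)ccc2OC)c1` share one core; compound 2 `COc1ccc(-c2cn(C3Cc4ccc(O[C@@H]5OC(C)(C)[C@H](OC)[C@@H](O)[C@H]5O)c(C)c4OC3=O)nn2)cc1` and compound 4 `COc1cccc(-c2cc(-c3cn(C4Cc5ccc(O[C@@H]6OC(C)(C)[C@H](OC)[C@@H](O)[C@H]6O)c(C)c5OC4=O)nn3)ccc2OC)c1` share another, and the difference between the two cores is not broken down here. In a functional assay on MCF7 cells (Homo sapiens) for antiproliferative activity (on this read-out lower numbers stand for stronger inhibition and higher numbers for weaker inhibition), compound 1 gives only a limit, > 100000 nM. Compound 2 likewise gives only a limit, > 100000 nM. Compound 3 gives 28000 nM. The change 3-methoxyphenyl in place of hydrogen on an aromatic carbon brings an at least 3.5-fold lower number from compound 1 to compound 3 (0.55 log units; beyond the scatter); the step is bounded on one side only because compound 1 sits at the limit of > 100000 nM in this assay, at which 2 of the 3 values shown sit. The same change, (3-methoxyphenyl in place of hydrogen on an aromatic carbon), leads to compound 4. The step of an at least 2.5-fold lower number from compound 2 to compound 4 (0.39 log units; beyond the scatter) is expected to be of similar size, resting solely on an at least 3.5-fold lower number from compound 1 to compound 3 (0.55 log units; beyond the scatter). Compound 4 is therefore estimated at 40000 nM, with a real chance that only a limit is returned.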

Compound 4, half-maximal inhibitory concentration: 13200 nM
The estimate for compound 4 lay 3.0-fold (0.48 log units) above the measured number, and the stated range covers the measured number.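

In this assay, adding 3-methoxyphenyl to the core of compound 2 brings an at least 7.5-fold lower number from compound 2 to compound 4 (0.87 log units; beyond the scatter), so the direction seen on the core of compound 1 carries over to this second core. This rests on two pairs only and shows no more than a shared direction, and whether the size of the step carries over stays unresolved: the same change on two cores in this assay, an at least 3.5-fold lower number (0.55 log units; beyond the scatter) from compound 1 to compound 3 and an at least 7.5-fold lower number (0.87 log units; beyond the scatter) from compound 2 to compound 4; the limit leaves it open whether they differ. Both steps start from the same assay limit, so only a lower bound is known for each: the limit of > 100000 nM in this assay, at which 2 of the 4 values shown sit.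

As far as these compounds go, it remains open whether the drop in the number needs the methoxy group on the added ring, or whether an unsubstituted phenyl would also give it. Also open, from the compounds shown here alone, is how an amine or a carboxylic acid on that added ring would behave on either core.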